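This account rests on a few compounds, and the source may have more. Where it says the series, first, only, none or still open, it means among the compounds named here.

Compound 3 `CC[C@@H](Nc1c(C#N)c(-c2ccc(-c3cccc(CO)c3)cc2)nc2cnccc12)C(N)=O` carries a nitrile on its shared core and an amide side chain; in a physicochemical assay for lipophilicity, read by HPLC, at pH 7.5 (on this read-out higher numbers stand for higher lipophilicity and lower numbers for lower lipophilicity), compound 3 gives 2. Compound 1 `CC[C@H](Nc1c(C#N)c(-c2ccc(Br)cc2)nc2cnccc12)C(N)=O` gives 2.3 in this assay, a number that lies within the usual scatter of compound 3, so the two cannot be told apart. Compound 2 `CCOc1ccccc1-c1ccc(-c2nc3cnccc3c(C[C@H](C)C(N)=O)c2C#N)cc1` gives 3 in this assay, which sits beyond the scatter above compound 3. Compound 4 `CC[C@@H](Nc1c(C#N)c(-c2ccc(-c3cccc(OC)c3)cc2)nc2cnccc12)C(N)=O` differs from compound 3 in one place: methoxy in place of hydroxymethyl on an aromatic carbon. Among the measured compounds shown here, no measured pair shows this exchange, so the expectation rests on the structures alone. An upward step of a number 0.80 log units higher from compound 3 to compound 4 (beyond the scatter) is expected, reaching beyond the scatter. Compound 4 is estimated at 2.8, between 2.4 and 3.3.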

Compound 4, distribution coefficient: 2.7
The estimate for compound 4 lay 0.10 log units above the measured number; low and high end bracket the measured number.
By their numbers in this assay, from the lowest: compounds 3 and 1 (each within the scatter of the next); then compounds 4 and 2 (each within the scatter of the next).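

Among the compounds shown here, putting methoxy in place of hydroxymethyl on this aromatic carbon gives a number 0.70 log units higher from compound 3 to compound 4 (beyond the scatter) in this assay, the first comparison here of compounds that differ in one place. The two groups have the same atoms joined differently, with the hydrogen-bond donor of hydroxymethyl absent from methoxy, so rearranging these atoms alone is enough to shift the number. No measurement here bears on why the number shifts. Still open, from the compounds shown here alone, is how an amine or a carboxylic acid at this place would read, and whether this exchange gives a similar step elsewhere on the molecule.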